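A few compounds are considered here, and "the series" means these few. Any claim that something is new, unique, unknown or untested is made for them only; others in the source may bear on it.

The measured compounds so far:
compound 1, `COc1ccc(S(=O)(=O)c2cnc3c(F)cccc3c2-c2ccc(Cl)cc2)cc1`, with 1.05 mL/min
compound 2, `COc1ccc(-c2c(S(=O)(=O)c3ccc(OC)cc3)cnc3c(F)cccc23)cc1`, with 2.12 mL/min

Both were tested in an ADME assay on microsomes from liver (Homo sapiens) for metabolic stability, tested at 2.5 uM; on this read-out higher numbers stand for fast clearance and lower numbers for slow clearance. Compound 1 gives 1.05 mL/min, the lowest of the two numbers; the nearest neighbour is compound 2, separated by the step of a 2.0-fold higher number from compound 1 to compound 2 (0.31 log units; beyond the scatter). That step is the only measured one, and it concerns a methoxy in place of chloro on an aromatic carbon.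

Compound 3, `O=S(=O)(c1cc(Cl)cc(Cl)c1)c1cnc2c(F)cccc2c1-c1ccc(Cl)cc1`, is not yet measured in this assay. Against compound 1 the difference is 3,5-dichlorophenyl in place of 4-methoxyphenyl on a sulfonyl sulfur. Among the measured compounds shown here, the group on the sulfonyl sulfur is untouched in the measured pair, so the step from compound 1 to compound 2 is at another place and gives no direct guide, and no other measured step exists. What remains is that compound 1 itself sits at the low end of the two numbers. With nothing to point in either direction, the expected step of a 1.3-fold higher number from compound 1 to compound 3 (0.12 log units; within the scatter) is small, not beyond the scatter. Compound 3 is therefore estimated at 1.4 mL/min, within a range from 0.6 mL/min to 3.2 mL/min.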

Compound 3, intrinsic clearance in a liver preparation (reported as CLH), per the amount of preparation that the assay uses: 0.78 mL/min
For compound 3 the middle estimate is 1.8-fold (0.25 log units) above the measured one; low and high end bracket the measured number.
By their numbers in this assay, from the lowest: compounds 3 and 1 (each within the scatter of the next); then compound 2.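

In this assay, compound 1 and compound 2 differ elsewhere, so compound 3 is the one that speaks to the group on the sulfonyl sulfur: putting 3,5-dichlorophenyl in place of 4-methoxyphenyl gives a 1.3-fold lower number from compound 1 to compound 3 (0.13 log units; within the scatter). This change alters the atoms of that group considerably, with the oxygen of the methoxy gone and chlorine present instead, yet the read-out stays within the scatter, so at this place these two aromatic groups cannot be told apart by this measurement. Nothing available explains why the read-out holds across this change.

What the compounds leave open is how far this holds for groups of another kind on the sulfonyl sulfur, such as a morpholine, a carboxylic acid or a short alkyl chain, since both groups seen there so far are substituted phenyl rings. On these data alone, it is also open whether 3,5-dichlorophenyl would give a similar result on the core of compound 2, where the methoxy in place of chloro already gave a 2.0-fold higher number from compound 1 to compound 2 (0.31 log units; beyond the scatter).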